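Replacing furan-2-yl on the hydrazone-free numbers: a first look

The source may report more compounds than this note shows. Statements on the series, on what has been measured and on what is new or still open speak of the compounds shown alone.

In a functional assay on EC9706 cells (Homo sapiens) for antiproliferative activity, read by MTT assay, with a stated time of 72 h (a lower number here means a stronger inhibitor, a higher number a weaker inhibitor), compound 2 `O=C(N/N=C/c1ccco1)c1cccc(S(=O)(=O)N2CCOCC2)c1` stands at > 100000 nM, which is a limit of the assay and not a number. Compound 1 `C/C(=N\NC(=O)c1cccc(S(=O)(=O)N2CCOCC2)c1)c1cc(Br)ccc1O` gives a measured 24700 nM. Compound 3 `O=C(N/N=C/c1cc(Br)cc(Br)c1O)c1cccc(S(=O)(=O)N2CCOCC2)c1` carries 3,5-dibromo-2-hydroxyphenyl in place of furan-2-yl on a carbon with a double bond to nitrogen. With compound 1 at 24700 nM as the only numeric reference, a stronger reading in this assay is expected for compound 3. The estimated size of this change is an at least 6.6-fold lower number from compound 2 to compound 3 (0.82 log units; beyond the scatter). For compound 3 the expected value is 15000 nM, with an estimated range of 4000 nM to 50000 nM.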

Compound 3, half-maximal inhibitory concentration: 2440 nM
Compound 3: middle estimate off by 6.1-fold (0.79 log units), on the high side, and the stated range ends above it.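

In this assay, the group on a carbon with a double bond to nitrogen clearly matters: 3,5-dibromo-2-hydroxyphenyl in place of furan-2-yl gives an at least 40-fold lower number from compound 2 to compound 3 (1.61 log units; beyond the scatter). This step is a lower bound and not a full size, because compound 2 rests on a limit of the assay: the limit of > 100000 nM in this assay, at which 1 of the 3 values shown sits.

The change swaps the ring, the two bromines and the hydroxyl together, and the compounds shown do not separate these parts. From the compounds shown here alone, how a plain 2-hydroxyphenyl or a 3,5-dibromophenyl would read at this position remains open.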